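The compounds below may be only part of what the source reports. "The series", "measured", "known", "first", "only" and "open" are said of these compounds alone.

In a functional assay on A549 cells (Homo sapiens) for cytotoxicity, read by MTT assay, with a stated time of 72 h (a lower number here means a stronger inhibitor, a higher number a weaker inhibitor), three compounds on a shared core have been measured: compound 1 `O=C1c2c[n+]([O-])c3ccccc3c2C(=O)c2c1c1ccccc1n2Cc1cn([C@@H]2C[C@H](O)[C@@H](CO)O2)nn1` gives 120 nM, compound 2 `O=C1c2c[n+]([O-])c3ccccc3c2C(=O)c2c1c1ccccc1n2Cc1cn(CC(O)CO)nn1` gives 880 nM and compound 3 `CC1(C)OC[C@H](Cn2cc(Cn3c4c(c5ccccc53)C(=O)c3c[n+]([O-])c5ccccc5c3C4=O)nn2)O1` gives 340 nM. Compound 3 therefore holds the middle of the three numbers.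

The next member is compound 4 `O=C1c2c[n+]([O-])c3ccccc3c2C(=O)c2c1c1ccccc1n2Cc1cn([C@@H]2O[C@H](CO)[C@@H](O)[C@H](O)[C@H]2O)nn1`. The change from compound 3 is 3,4,5-trihydroxy-6-(hydroxymethyl)oxan-2-yl in place of (2,2-dimethyl-1,3-dioxolan-4-yl)methyl on an aromatic nitrogen.

All three measured steps were made at this same place, and all are modest and beyond the scatter. The series shows a 2.8-fold higher number from compound 1 to compound 3 (0.45 log units; beyond the scatter) and a 2.6-fold lower number from compound 2 to compound 3 (0.41 log units; beyond the scatter), while the widest is a 7.3-fold higher number from compound 1 to compound 2 (0.87 log units; beyond the scatter). Compound 1 and compound 2 both carry free hydroxyl groups, yet they fall on opposite sides of compound 3, so hydroxyl groups alone set no direction. No oxan-2-yl group has been measured in the series.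

In this assay no step beyond the scatter is therefore expected, although a modest step in either direction remains possible. The estimated step is a 1.1-fold lower number from compound 3 to compound 4 (0.05 log units; within the scatter). For compound 4 the expected value is 300 nM, with an estimated range of 100 nM to 1000 nM.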

Compound 4, half-maximal inhibitory concentration: 560 nM
The estimate for compound 4 lay 1.9-fold (0.27 log units) below the measured number; measured number inside the range.
By their numbers in this assay, from the lowest: compound 1; then compounds 3, 4 and 2 (each within the scatter of the next, the first and the last beyond it).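

In this assay, the 3,4,5-trihydroxy-6-(hydroxymethyl)oxan-2-yl group on the aromatic nitrogen cannot be separated from either of two other groups at this place, the (2,2-dimethyl-1,3-dioxolan-4-yl)methyl group (a 1.6-fold higher number from compound 3 to compound 4 (0.22 log units; within the scatter)) or the 2,3-dihydroxypropyl group (a 1.6-fold lower number from compound 2 to compound 4 (0.20 log units; within the scatter)). The exchange of a group with 0 hydrogen-bond donors for one with 4 therefore leaves no step beyond the scatter, whereas the 4-hydroxy-5-(hydroxymethyl)oxolan-2-yl group of compound 1 keeps its distance, now also (a 4.7-fold higher number from compound 1 to compound 4 (0.67 log units; beyond the scatter)), and compound 1 remains the strongest of the four. No measurement on hand accounts for these steps.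

The step to compound 4 changes ring size and the number of hydroxyl groups together, so the compounds shown do not tell which of the two separates it from compound 1. Also open, on these data alone, is how the number responds to an amine or a carboxylic acid on the ring carried by the aromatic nitrogen, since every group here bears only hydroxyl or ether oxygens.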